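Filling an Open Ring Position with a Chloropyridinyloxy Group

The compounds below may be only part of what the source reports. "The series", "measured", "known", "first", "only" and "open" are said of these compounds alone.

Three compounds have been measured in a functional assay for inhibition of sodium/hydrogen exchanger (Oryctolagus cuniculus); a higher number here means a weaker inhibitor, a lower number a stronger inhibitor:
compound 1, `Cc1cc(OC2CCCC2)c(S(C)(=O)=O)cc1C(=O)N=C(N)N`: 27 nM
compound 2, `Cc1cc(C(F)(F)F)c(S(C)(=O)=O)cc1C(=O)N=C(N)N`: 37 nM
compound 3, `Cc1ccc(S(C)(=O)=O)cc1C(=O)N=C(N)N`: 150 nM

Compound 3 gives the highest number of the three. Both steps that lead to it point the same way: a 5.6-fold higher number from compound 1 to compound 3 (0.74 log units; beyond the scatter) and a 4.1-fold higher number from compound 2 to compound 3 (0.61 log units; beyond the scatter), each marking the loss of a group from the same ring carbon. Compound 4, `Cc1cc(Oc2cncc(Cl)c2)c(S(C)(=O)=O)cc1C(=O)N=C(N)N`, reverses this loss with a new group: (5-chloropyridin-3-yl)oxy in place of hydrogen on an aromatic carbon. Compound 1 shares the oxygen link with it, so its step is the closest guide. For compound 4 the number in this assay is expected to fall, a 4.3-fold lower number from compound 3 to compound 4 (0.63 log units; beyond the scatter), to an estimated 35 nM, within a range from 12 nM to 100 nM.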

Compound 4, half-maximal inhibitory concentration: 14 nM
Beside the measured number, compound 4's estimate is 2.5-fold (0.40 log units) above it; measured number inside the range.
By their numbers in this assay, from the lowest: compounds 4, 1 and 2 (each within the scatter of the next, the first and the last beyond it); then compound 3.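

In this assay, this ring carbon accepts an aromatic ring on the oxygen, and (5-chloropyridin-3-yl)oxy brings the largest change seen so far (an 11-fold lower number from compound 3 to compound 4 (1.03 log units; beyond the scatter)). The group also outperforms trifluoromethyl (a 2.6-fold lower number from compound 2 to compound 4 (0.42 log units; beyond the scatter)), while 5-chloropyridin-3-yl and cyclopentyl on the same oxygen cannot be told apart (a 1.9-fold lower number from compound 1 to compound 4 (0.29 log units; within the scatter)). No measurement available here explains these differences.

On these data alone, whether the chlorine or the ring nitrogen contributes remains open, since neither is varied alone. Also open, as far as these compounds go, is how a plain phenoxy group or an amine would fare at this ring carbon.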